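The compounds below may be only part of what the source reports. "The series", "measured", "known", "first", "only" and "open" are said of these compounds alone.

Compound 3 `CNC(=O)COc1ccncc1-c1ccc2ccccc2c1` gives 4% in an assay on a protein complex for inhibition of CDK8/Cyclin C (Homo sapiens), with a stated time of 1 h, tested at 10 uM (a higher number here means more inhibition at the concentration tested (going by the name of the read-out), a lower number less inhibition), the lowest of the three measured numbers. Compound 1 `NNC(=O)COc1ccncc1-c1ccc2ccccc2c1` gives 19%, and compound 2 `O=C(/C=C/c1ccncc1-c1ccc2ccccc2c1)NC1CC1` gives 102%. The steps down to compound 3 are a number 15 percentage points lower from compound 1 to compound 3 (beyond the scatter) and a number 98 percentage points lower from compound 2 to compound 3 (beyond the scatter). Compound 4 `COC(=O)COc1ccncc1-c1ccc2ccccc2c1` differs from compound 3 by methoxy in place of methylamino on a carbonyl carbon. Among the compounds with values here, no measured step touches this carbonyl carbon. The nearest comparison is the modest change on the amide-type nitrogen, a number 15 percentage points lower from compound 1 to compound 3 (beyond the scatter), while the large step of a number 98 percentage points lower from compound 2 to compound 3 (beyond the scatter) concerns another place on the shared core. Compound 4 is therefore expected to stay low, with an estimated step of a number 2 percentage points higher from compound 3 to compound 4 (within the scatter) that need not exceed the scatter. Compound 4 is estimated at 6%, ranging from -10% to 22%.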

Compound 4, a percentage reported as inhibition, at one concentration (the size of the read-out at that concentration, not a potency): 11%
For compound 4 the middle estimate is 5 percentage points below the measured one, within the range that was stated.
By their numbers in this assay, from the lowest: compounds 3, 4 and 1 (each within the scatter of the next, the first and the last beyond it); then compound 2.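

Methoxy in place of methylamino on the carbonyl carbon, a place no earlier step had touched, gives a number 7 percentage points higher from compound 3 to compound 4 (within the scatter), so losing this amide hydrogen leaves the number within the scatter. Methoxy in place of aminoamino on the same carbon gives a number 8 percentage points lower from compound 1 to compound 4 (within the scatter), also within the scatter, while the (methoxycarbonyl)methoxy compound stays far from the ethenyl amide, a number 91 percentage points lower from compound 2 to compound 4 (beyond the scatter). No evidence at hand accounts for these numbers. Open, as far as these compounds go, is whether a carboxylic acid or a longer ester chain on this carbonyl carbon would change the number, and whether compound 2 would hold its number with methoxy on its carbonyl carbon in place of the cyclopropylamino group.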